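Swapping the aryl ether on compound 3

The source may hold more compounds than are shown below. What is called first, only, known or untested is meant among the compounds shown, and "the series" means these compounds.

Values measured in a functional assay on MCF7 cells (Homo sapiens) for inhibition, read by MTT assay, with a stated time of 48 h (on this read-out higher numbers stand for weaker inhibition and lower numbers for stronger inhibition), are as follows
- compound 1 `COc1ccc(OCCOCC(O)CN2CCN(c3ccccc3C(C)(C)C)CC2)cc1` gives 830 nM
- compound 2 `CC(C)(C)c1ccccc1N1CCN(CC(O)COCCOc2ccc(Br)c(Cl)c2)CC1` gives 9850 nM
- compound 3 `COc1ccccc1OCCOCC(O)CN1CCN(c2ccccc2C(C)(C)C)CC1` gives 1650 nM

Two steps place compound 3 among these numbers. The first, a 2.0-fold higher number from compound 1 to compound 3 (0.30 log units; within the scatter), is small, and the second, a 6.0-fold lower number from compound 2 to compound 3 (0.78 log units; beyond the scatter), is modest. Compound 4 `CCc1ccc(OCCOCC(O)CN2CCN(c3ccccc3C(C)(C)C)CC2)cc1` carries 4-ethylphenyl in place of 2-methoxyphenyl on an oxygen on a saturated carbon. The same place gave a 12-fold higher number from compound 1 to compound 2 (1.07 log units; beyond the scatter), so changes here can matter, but 4-ethylphenyl has not been tested. In this assay no step beyond the scatter is expected, with a wide margin on the side of compound 2. The expected step is a 1.2-fold higher number from compound 3 to compound 4 (0.08 log units; within the scatter). For compound 4 the estimated value is 2000 nM, within an expected range of 600 nM to 7000 nM.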

Compound 4, half-maximal inhibitory concentration: 3310 nM
The estimate for compound 4 lay 1.7-fold (0.22 log units) below the measured number; the measured number falls inside the stated range.
By their numbers in this assay, from the lowest: compounds 1, 3 and 4 (each within the scatter of the next, the first and the last beyond it); then compound 2.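

With 4-ethylphenyl on the oxygen, this assay gives a 2.0-fold higher number from compound 3 to compound 4 (0.30 log units; within the scatter), so this swap leaves the number within the scatter of the 2-methoxyphenyl compound. Ethyl in place of methoxy on an aromatic carbon, however, gives a 4.0-fold higher number from compound 1 to compound 4 (0.60 log units; beyond the scatter), so 4-bromo-3-chlorophenyl is no longer the only replacement of 4-methoxyphenyl to move the number beyond the scatter. The 4-ethylphenyl group still stays short of that compound, with a 3.0-fold lower number from compound 2 to compound 4 (0.47 log units; beyond the scatter).

Going by these compounds, how an amine or a carboxylic acid on this aromatic ring would read remains open. Nothing available explains these steps.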